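Weakening the amide back toward an open chain

The source may report more compounds than this note shows. Statements on the series, on what has been measured and on what is new or still open speak of the compounds shown alone.

Compound 1 `CC(C)(C)OC(=O)NCCCNC(=O)CN1CN(c2ccccc2)C2(CCN(C(=O)c3ccc(C4CCCCC4)cc3)CC2)C1=O` gives 6000 nM in an assay on HEK293 cells for displacement of a labelled ligand from NPC1-like intracellular cholesterol transporter 1 (Homo sapiens); a lower number here means a stronger inhibitor, a higher number a weaker inhibitor.
Compound 2 `O=C(CN1CN(c2ccccc2)C2(CCN(C(=O)c3ccc(C4CCCCC4)cc3)CC2)C1=O)N1CCC(CO)CC1` gives 1100 nM in this assay.
Compound 3 `CCC1CCCN(C(=O)CN2CN(c3ccccc3)C3(CCN(C(=O)c4ccc(C5CCCCC5)cc4)CC3)C2=O)C1` gives 2600 nM in this assay.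

Compound 3 holds the second highest number of the three, sitting nearer to compound 1 than to compound 2; the change from compound 1 to compound 3 was a 2.3-fold lower number from compound 1 to compound 3 (0.36 log units; beyond the scatter), and from compound 2 to compound 3 it was a 2.4-fold higher number from compound 2 to compound 3 (0.37 log units; beyond the scatter). Compound 4 `COC(=O)CCCNC(=O)CN1CN(c2ccccc2)C2(CCN(C(=O)c3ccc(C4CCCCC4)cc3)CC2)C1=O` differs from compound 3 by (3-(methoxycarbonyl)propyl)amino in place of 3-ethylpiperidin-1-yl on a carbonyl carbon. This returns the amide to an open-chain secondary amide, as in compound 1. The step of a 2.3-fold lower number from compound 1 to compound 3 (0.36 log units; beyond the scatter) bears directly on it, as does a 5.5-fold lower number from compound 1 to compound 2 (0.74 log units; beyond the scatter), which shows that the cyclic amides gave the lower numbers. Running that step in reverse, the number is expected to rise beyond the scatter, giving a 1.7-fold higher number from compound 3 to compound 4 (0.24 log units; within the scatter). Compound 4 is therefore estimated at 4500 nM, with a range from 1800 nM to 11000 nM.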

Compound 4, half-maximal inhibitory concentration: 2500 nM
Beside the measured number, compound 4's estimate is 1.8-fold (0.26 log units) above it; the measured number falls inside the stated range.
By their numbers in this assay, from the lowest: compound 2; then compounds 4 and 3 (each within the scatter of the next); then compound 1.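

At this carbonyl carbon, an open chain does not by itself bring a higher number in this assay: there is a 1.0-fold lower number from compound 3 to compound 4 (0.02 log units; within the scatter), so (3-(methoxycarbonyl)propyl)amino and 3-ethylpiperidin-1-yl cannot be told apart here. The earlier link between cyclic amides and lower numbers therefore does not hold generally, as there is a 2.3-fold higher number from compound 2 to compound 4 (0.36 log units; beyond the scatter) but also a 2.4-fold lower number from compound 1 to compound 4 (0.38 log units; beyond the scatter), which places compound 4 against that pattern and shows that the end of the open chain matters. No measurement available here accounts for these differences.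

As far as these compounds go, whether the lower number of compound 2 goes with its ring or with its hydroxymethyl group remains open, and a plain piperidin-1-yl group on this carbonyl carbon would bear on that. Equally open, from the compounds shown here alone, is how a carboxylic acid in place of the methoxycarbonyl, or a longer chain, would read.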